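Chain Extension and Configuration Across Four Compounds

A few compounds are considered here, and "the series" means these few. Any claim that something is new, unique, unknown or untested is made for them only; others in the source may bear on it.

Compound 1 `CCCCCCCCn1cc(COC[C@@H]2OC[C@H](N)[C@@H]2O)nn1` and compound 2 `CCCCCCCCCn1cc(COC[C@@H]2OC[C@H](N)[C@@H]2O)nn1` share one core. In a functional assay on EC9706 cells (Homo sapiens) for antiproliferative activity, read by MTT assay, with a stated time of 48 h (a higher number here means a weaker inhibitor, a lower number a stronger inhibitor), compound 1 gives 44300 nM, and compound 2 gives 20100 nM. The difference between them is methyl in place of hydrogen on a saturated chain carbon, eight bonds along the chain from an aromatic nitrogen, and the step was a 2.2-fold lower number from compound 1 to compound 2 (0.34 log units; beyond the scatter). Compound 3 `CCCCCCCCCn1cc(COC[C@@H]2OC[C@H](N)[C@H]2O)nn1` has the same atoms and bonds as compound 2; the step was an at least 6.3-fold higher number from compound 2 to compound 3 (0.80 log units; beyond the scatter), which rests on (the fact that compounds 2 and 3 differ only in the configuration as drawn). In this assay compound 3 gives only a limit, > 128000 nM. The difference between the cores of compound 1 and compound 3 is not broken down here. Compound 4 `CCCCCCCCCCn1cc(COC[C@@H]2OC[C@H](N)[C@H]2O)nn1` differs from compound 3 by methyl in place of hydrogen on a saturated chain carbon, nine bonds along the chain from an aromatic nitrogen, the same kind of change, now nine rather than eight bonds along the chain from an aromatic nitrogen. The estimated step is a step that the limit leaves unreadable from compound 3 to compound 4. That expectation rests on a 2.2-fold lower number from compound 1 to compound 2 (0.34 log units; beyond the scatter) and on (the limit of > 128000 nM in this assay, at which 1 of the 3 values shown sits). Compound 4 is expected to give about 150000 nM in this assay, between 60000 nM and 400000 nM, and may return only a limit.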

Compound 4, half-maximal inhibitory concentration: 43100 nM
Compound 4: the middle estimate sits 3.5-fold (0.54 log units) above what was measured; measured number outside the range, below it.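

In this assay, methyl in place of hydrogen on a saturated chain carbon, nine bonds along the chain from an aromatic nitrogen, gave an at least 2.9-fold lower number from compound 3 to compound 4 (0.47 log units; beyond the scatter), so the change lowers the number on this core as it did, eight bonds along the chain, on the core of compound 1. For compound 3 the reading in this assay is only a limit, > 128000 nM. The direction therefore carries over between these two pairs, but the size of the step on the second core cannot be fixed, nor can it be said to match the first: the same change on two cores in this assay, a 2.2-fold lower number (0.34 log units; beyond the scatter) from compound 1 to compound 2 and an at least 2.9-fold lower number (0.47 log units; beyond the scatter) from compound 3 to compound 4; the limit leaves it open whether they differ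

The compounds shown leave open how a longer chain would read on either core. They also leave open whether an ether or an amide in place of the amine would keep the gap between the two configurations.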